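Shifting the furan attachment point on a nucleoside core

The source may report more compounds than this note shows. Statements on the series, on what has been measured and on what is new or still open speak of the compounds shown alone.

Compound 1 `COc1ncnc2c1c(-c1ccoc1)cn2[C@@H]1O[C@H](CO)[C@@H](O)[C@H]1O`: in a functional assay on K562 cells (Homo sapiens), read by MTT assay, with a stated time of 72 h (on this read-out lower numbers stand for stronger inhibition and higher numbers for weaker inhibition), compound 1 gives 190 nM.
Compound 2 `COc1nc(N)nc2c1c(-c1ccoc1)cn2[C@@H]1O[C@H](CO)[C@@H](O)[C@H]1O`: compound 2 reaches only an assay limit, > 20000 nM.
Compound 3 `CNc1ncnc2c1c(-c1ccoc1)cn2[C@@H]1O[C@H](CO)[C@@H](O)[C@H]1O`: compound 3 likewise reaches only an assay limit, > 20000 nM.

Among the measured compounds shown here, compound 1 thus stands as the only compound here with a real number; the other two values are limits. The two measured changes to it are an at least 100-fold higher number from compound 1 to compound 2 (2.02 log units; beyond the scatter) and an at least 100-fold higher number from compound 1 to compound 3 (2.02 log units; beyond the scatter), and both run to the limit of > 20000 nM in this assay, at which 2 of the 3 values shown sit.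

Compound 4 `COc1ncnc2c1c(-c1ccco1)cn2[C@@H]1O[C@H](CO)[C@@H](O)[C@H]1O` is not yet measured. It differs from compound 1 by furan-2-yl in place of furan-3-yl on an aromatic carbon. Neither of the measured steps touches the furan; both alter a different part of the shared core. So no measured step bears on this change, and the two large losses seen elsewhere give no direct guide to its size or direction. With no comparison available, the expectation has to be cautious: a regioisomeric swap of this kind may be tolerated or may weaken potency, and the estimate is widened accordingly. Compound 4 is expected to give about 600 nM, within 150 nM to 5000 nM. This amounts to an expected step of a 3.2-fold higher number from compound 1 to compound 4 (0.50 log units; beyond the scatter), an estimate rather than a measurement.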

Compound 4, half-maximal inhibitory concentration: 60 nM
For compound 4 the middle estimate is 10-fold (1.00 log units) above the measured one; the whole stated range lies above it.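

The aromatic carbon that bears the furan turns out to respond to how the ring is joined: in this assay, moving from furan-3-yl to furan-2-yl gives a 3.2-fold lower number from compound 1 to compound 4 (0.50 log units; beyond the scatter), a step towards stronger inhibition that goes beyond the scatter, even though both groups have the same atoms and the same counted donors and acceptors. This is the only change shown at this carbon, and the only one shown that improves on compound 1, so the furan is a place where a small rearrangement can be tolerated and even favoured, whereas the two changes made elsewhere on the shared core end differently, at an assay limit: the limit of > 20000 nM in this assay, at which 2 of the 4 values shown sit.
Nothing measured here accounts for the difference between the two furan attachments.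

On these data alone, whether furan-2-yl would give the same benefit alongside the amino group of compound 2 or the methylamino group of compound 3 remains open. Also open, as far as these compounds go, is how a different ring on this same aromatic carbon, such as thiophen-2-yl or phenyl, would compare with furan-2-yl in this cell assay.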